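Swapping the Oxime for Trifluoromethoxy on the Shared Core

A few compounds are considered here, and "the series" means these few. Any claim that something is new, unique, unknown or untested is made for them only; others in the source may bear on it.

Of the compounds shown here, three built on a shared core have been measured in an assay on isolated protein for inhibition of long-chain fatty acid transport protein 1 (Mus musculus); on this read-out lower numbers stand for stronger inhibition and higher numbers for weaker inhibition. Compound 1 `CCc1ccc2oc(CSc3nnc(CNc4ccccc4)n3CC)nc2c1` gives 1800 nM. Compound 3 `CC/C(=N/O)c1ccc2oc(CSc3nnc(CNc4ccccc4)n3CC)nc2c1` gives 200 nM, the lowest of the two numbers shown. Compound 2 `CC/C(=N/OC)c1ccc2oc(CSc3nnc(CNc4ccccc4)n3CC)nc2c1` reaches only the limit of this assay at > 10000 nM. Replacing the ethyl with an uncapped oxime brought a 9.0-fold lower number from compound 1 to compound 3 (0.95 log units; beyond the scatter), while the methyl-capped oxime instead gave an at least 5.5-fold higher number from compound 1 to compound 2 (0.74 log units; beyond the scatter); removing that methyl from the oxime oxygen gave an at least 50-fold lower number from compound 2 to compound 3 (1.69 log units; beyond the scatter).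

Compound 4 `CCn1c(CNc2ccccc2)nnc1SCc1nc2cc(OC(F)(F)F)ccc2o1` has not yet been measured and differs from compound 3 by a group of 5 heavy atoms (1 carbon, 1 oxygen, 3 fluorine; no ring) in place of a group of 5 heavy atoms (3 carbon, 1 nitrogen, 1 oxygen; no ring), on an aromatic carbon. The group that enters carries no hydrogen-bond donor, and both measured compounds without such a donor, compound 1 and compound 2, sit well above compound 3 in this assay. For the measured compounds named here, the new step is therefore expected to move the number upward, by a modest to large amount, though the trifluoromethoxy group itself has no measured precedent here. Compound 4 is expected to give about 3000 nM, most likely between 600 nM and 15000 nM. That estimate means an expected 15-fold higher number from compound 3 to compound 4 (1.18 log units; beyond the scatter).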

Compound 4, half-maximal inhibitory concentration: 91 nM
Compound 4: the middle estimate sits 33-fold (1.52 log units) above what was measured; measured number outside the range, below it.
By their numbers in this assay, from the lowest: compound 4; then compound 3; then compound 1. At a limit, above all of these: compound 2.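

In this assay, a 2.2-fold lower number from compound 3 to compound 4 (0.34 log units; beyond the scatter), so among these compounds a hydrogen-bond donor at this position on the aromatic carbon is not needed for the lowest number, even though trifluoromethoxy carries none. Lacking a donor does not by itself decide the outcome: compound 1 and compound 2 also lack one, and trifluoromethoxy in place of ethyl gives a 20-fold lower number from compound 1 to compound 4 (1.30 log units; beyond the scatter). The widest comparison, an at least 100-fold lower number from compound 2 to compound 4 (2.04 log units; beyond the scatter), rests on a limit rather than a number: the limit of > 10000 nM in this assay, at which 1 of the 4 values shown sits.

On these data alone, whether methoxy, trifluoromethyl or a chlorine atom at this position would stay close to compound 4 remains open, and the part played by the fluorine atoms cannot yet be separated. As far as these compounds go, it is also open how an amine or a carboxylic acid here would compare with the oxime of compound 3.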